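Lengthening an Amine Side Chain on Two Different Cores

The source may report more compounds than this note shows. Statements on the series, on what has been measured and on what is new or still open speak of the compounds shown alone.

Compound 1 `CN(C)CCCCn1c(N)c(-c2nc3ccccc3o2)c2nc(C#N)c(C#N)nc21` carries a dimethylamino group on a chain attached to a ring nitrogen of its core. In a functional assay on cells (Homo sapiens) for antiproliferative activity, read by MTT assay, with a stated time of 48 h (a higher number here means a weaker inhibitor, a lower number a stronger inhibitor), compound 1 gives 6130 nM. Compound 2 `CCN(CC)CCCCn1c(N)c(-c2nc3ccccc3o2)c2nc(C#N)c(C#N)nc21` differs from it only by diethylamino in place of dimethylamino on a saturated chain carbon, four bonds along the chain from an aromatic nitrogen. In this assay compound 2 gives 2710 nM, which amounts to a 2.3-fold lower number from compound 1 to compound 2 (0.35 log units; beyond the scatter).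

Compound 3 `CN(C)CCn1c(N)c(-c2nc3ccccc3n2C)c2nc(C#N)c(C#N)nc21` is built on a different core; how the core of compound 3 differs from the core of compound 1 is not broken down here. In this assay compound 3 gives only a limit, > 50000 nM, meaning the measurement returned no number for it. Compound 4 `CCN(CC)CCn1c(N)c(-c2nc3ccccc3n2C)c2nc(C#N)c(C#N)nc21`, not yet measured, differs from compound 3 by diethylamino in place of dimethylamino on a saturated chain carbon, two bonds along the chain from an aromatic nitrogen. The surroundings are not identical to those in the first pair: there the change sat four bonds along the chain from an aromatic nitrogen, here it sits two bonds along the chain from an aromatic nitrogen, so this is the same kind of change rather than the same change.

Going by the values given here, compound 3 sits at the limit of > 50000 nM in this assay, at which 1 of the 3 values shown sits, so even a gain as large as the one from compound 1 to compound 2 would be expected to leave compound 4 close to that limit. The expected step from compound 3 to compound 4 is therefore an at least 1.1-fold lower number from compound 3 to compound 4 (0.04 log units; that floor lies within the scatter). Compound 4 is estimated at 45000 nM, with a real chance that this assay again reports only a limit.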

Compound 4, half-maximal inhibitory concentration: > 50000 nM
Compound 4 ended at the assay's limit; the forecaster's own chance of this, stated with the estimate: 65%; at least 1.1-fold (0.04 log units) between middle value and limit.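

Compound 3 and compound 4 both return only a limit rather than a number, so no step can be read between them: the limit of > 50000 nM in this assay, at which 2 of the 4 values shown sit.

As far as these compounds go, what stays open is where each of the two truly lies beyond that limit, and whether diethylamino in place of dimethylamino has any effect on this core comparable to a 2.3-fold lower number from compound 1 to compound 2 (0.35 log units; beyond the scatter).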